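Cytotoxicity of a Fluoro-for-Methyl Swap in Compound 4

The compounds below may be only part of what the source reports. "The series", "measured", "known", "first", "only" and "open" are said of these compounds alone.

In a functional assay on MT4 cells (Homo sapiens) for cytotoxicity, read by MTT assay, with a stated time of 5 days (on this read-out higher numbers stand for lower toxicity in this test and lower numbers for higher toxicity in this test), every measured compound reached only the limit of the test:
Compound 1 `Cc1cc(C#N)ccc1-c1ccc(Oc2ccnc(Nc3ccc(C#N)cc3)n2)c(F)c1` gives the limit > 296000 nM.
Compound 2 `N#Cc1ccc(Nc2nccc(Oc3ccc(-c4ccc(C#N)c(F)c4)cc3F)n2)cc1` gives the limit > 294000 nM.
Compound 3 `Cc1cc(-c2ccc(C#N)cc2F)ccc1Oc1ccnc(Nc2ccc(C#N)cc2)n1` gives the limit > 296000 nM.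

Compound 3 thus stands at a limit, as do the other two, shown by the limit of > 294000 nM in this assay, at which 1 of the 3 values shown sits, and (the limit of > 296000 nM in this assay, at which 2 of the 3 values shown sit). Among the measured compounds shown here, the one measured step, a step that the two limits leave unreadable from compound 1 to compound 2, cannot be read because both ends are limits. Compound 4 `N#Cc1ccc(Nc2nccc(Oc3ccc(-c4ccc(C#N)cc4F)cc3F)n2)cc1` differs from compound 3 by fluoro in place of methyl on an aromatic carbon. For the measured compounds named here, no measured step gives a size for this change, so the step of a number no higher from compound 3 to compound 4 (the limit leaves the size open) is expected to stay unreadable, with compound 4 again at the limit. Compound 4 is estimated at 296000 nM, within 150000 nM to 600000 nM.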

Compound 4, half-maximal cytotoxic concentration: > 294000 nM
Compound 4 gave a limit, no number (the forecaster's own chance of this, stated with the estimate: 85%); the middle value is on the limit's open side.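

Among the compounds shown here, compound 4, like compound 1, compound 2 and compound 3, gives only a limit, so no step between compound 4 and the others can be read. The compounds shown leave open at what concentration any of them becomes toxic to these cells.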